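Methoxy in Place of Methyl: a Repeated Change

This account rests on a few compounds, and the source may have more. Where it says the series, first, only, none or still open, it means among the compounds named here.

Compound 1 `COc1ccc(C(=O)N2N=C(c3ccccc3)CC2c2cn(C)c3ccccc23)cn1`: 3130 nM
Compound 2 `Cc1ccc(C(=O)N2N=C(c3ccccc3)CC2c2cn(C)c3ccccc23)cn1`: 1220 nM
Compound 3 `COc1cccc(C2=NN(C(=O)c3ccc(C)nc3)C(c3cn(C)c4ccc(OC)cc34)C2)c1`: 29 nM

Of the compounds shown here, three have so far been tested in a functional assay on HepG2 cells (Homo sapiens) for inhibition, read by MTT assay, with a stated time of 48 h; a higher number here means a weaker inhibitor of growth, a lower number a stronger inhibitor of growth. Compound 1 and compound 2 share one core and differ in a single group: methoxy in place of methyl on an aromatic carbon. In this assay that swap gives a 2.6-fold higher number from compound 2 to compound 1 (0.41 log units; beyond the scatter), a weakening of growth inhibition that is modest but clearly beyond the usual scatter. Compound 3 is built on a different core; how its core differs from that of compound 2 is not broken down here. The values themselves show that compound 3 gives by far the lowest number of the three, with compound 2 the nearest of the other two and compound 1 the furthest away.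

Compound 4 `COc1cccc(C2=NN(C(=O)c3ccc(OC)nc3)C(c3cn(C)c4ccc(OC)cc34)C2)c1` has not yet been measured. It stands to compound 3 exactly as compound 1 stands to compound 2: methoxy in place of methyl on an aromatic carbon. The group that leaves, the group that enters and the place are the same in both pairs, so this is the same change, now made on the core of compound 3. Among the measured compounds shown here, only one measured instance of the change exists, and it was seen on another core, so the expectation carries some width. For compound 4 the expected step is a 2.4-fold higher number from compound 3 to compound 4 (0.38 log units; beyond the scatter), which rests on the measured 2.6-fold higher number from compound 2 to compound 1 (0.41 log units; beyond the scatter). Compound 4 is therefore estimated at 70 nM in this assay. Compound 4 is expected to fall between 25 nM and 200 nM.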

Compound 4, concentration for 50% growth inhibition: 190 nM
Compound 4: the middle estimate sits 2.7-fold (0.43 log units) below what was measured; low and high end bracket the measured number.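

On the core of compound 3, replacing 6-methylpyridin-3-yl with 6-methoxypyridin-3-yl gives in this assay a 6.6-fold higher number from compound 3 to compound 4 (0.82 log units; beyond the scatter) and so moves the number the same way as the earlier swap did, towards weaker growth inhibition. Set side by side, the two steps point in one direction and their sizes cannot be told apart, so in this small set the change carries over from one core to the other: the same change on two cores in this assay, a 2.6-fold higher number (0.41 log units; beyond the scatter) from compound 2 to compound 1 and a 6.6-fold higher number (0.82 log units; beyond the scatter) from compound 3 to compound 4, 2.6-fold (0.41 log units) apart, within the scatter of two such steps

Among the compounds shown here, this rests on only two pairs, however, so it does not show that the step would keep its direction or size on a third core, and it gives no reason why methoxy gives the higher number in both pairs. Compound 4 also stays far lower in number than compound 1 and compound 2, but that gap involves other differences and says nothing about this swap.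

The compounds shown leave open what other groups would do at the same place on the pyridine ring, such as an amine, a chlorine atom, a carboxylic acid or a longer chain like ethoxy. They also leave open whether the same swap would read alike on other cell lines.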